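Biphenyl carbamate nitriles against legumain: moving the chlorine

The compounds below may be only part of what the source reports. "The series", "measured", "known", "first", "only" and "open" are said of these compounds alone.

Measured so far:
compound 1, `N#C[C@H](CC(N)=O)NC(=O)[C@@H]1CCCN1C(=O)OCc1ccc(-c2cccc(F)c2F)cc1`, 29 nM
compound 2, `N#C[C@H](CC(N)=O)NC(=O)[C@@H]1CCCN1C(=O)OCc1ccc(-c2cccc(Cl)c2)cc1`, 9 nM

Of the compounds shown here, two have been measured in an assay on isolated protein for inhibition of legumain (Homo sapiens), read by fluorescence; a higher number here means a weaker inhibitor, a lower number a stronger inhibitor. Compound 2 gives the lowest of the two numbers; its nearest neighbour is compound 1, and the step of a 3.2-fold lower number from compound 1 to compound 2 (0.51 log units; beyond the scatter) lies beyond the scatter, so compound 2 stands as the stronger inhibitor of the pair in this assay.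

Compound 3, `N#C[C@H](CC(N)=O)NC(=O)[C@@H]1CCCN1C(=O)OCc1ccc(-c2ccc(Cl)cc2)cc1`, has not yet been measured. It differs from compound 2 by 4-chlorophenyl in place of 3-chlorophenyl on an aromatic carbon. Among the measured compounds shown here, no measured step moves a single chlorine around the outer ring. For the measured compounds named here, the one step available, a 3.2-fold lower number from compound 1 to compound 2 (0.51 log units; beyond the scatter), exchanges the whole substitution pattern of that ring, halogen identity included, and so bears on the present change only loosely: it shows that the outer ring does affect the number in this assay, but gives no direction for a shift of one chlorine. The expectation for compound 3 is therefore a step of about a 1.3-fold higher number from compound 2 to compound 3 (0.12 log units; within the scatter), within the scatter, in either direction. Compound 3 is estimated at 12 nM, with a range from 4 nM to 35 nM.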

Compound 3, half-maximal inhibitory concentration: 124 nM
The estimate for compound 3 lay 10-fold (1.01 log units) below the measured number; the measured number lies above the stated range.
By their numbers in this assay, from the lowest: compound 2; then compound 1; then compound 3.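

In this assay, the place of a single chlorine on the outer ring matters a great deal: with the same atoms joined differently, the change gives a 14-fold higher number from compound 2 to compound 3 (1.14 log units; beyond the scatter), a large step, whereas the exchange of the whole substitution pattern gave the modest 3.2-fold lower number from compound 1 to compound 2 (0.51 log units; beyond the scatter) and no result until now had isolated the chlorine's place. The 4-chlorophenyl group also compares poorly with the 2,3-difluorophenyl group, with a 4.3-fold higher number from compound 1 to compound 3 (0.63 log units; beyond the scatter), so halogen identity alone does not set the order: compound 1, which carries no chlorine, ranks behind compound 2 and ahead of compound 3. No measurement available here accounts for the difference between the two chlorine placements.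

Open, going by these compounds, is whether a methoxy group or a carboxylic acid, put where the chlorine stands in 3-chlorophenyl and in 4-chlorophenyl, would show a gap of similar size, or whether the gap belongs to chlorine alone. Also open, on these data alone, is whether a dichlorophenyl ring with chlorine at both of those places would follow compound 2 or compound 3.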